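The source may hold more compounds than are shown below. What is called first, only, known or untested is meant among the compounds shown, and "the series" means these compounds.

Of the compounds shown here, three built on the shared core have been measured in a physicochemical assay for solubility, in phosphate buffer, measured as kinetic solubility, with a stated time of 1 h, at pH 7.4; on this read-out higher numbers stand for higher solubility and lower numbers for lower solubility. Compound 1 `COc1ccc2nc(C)cc(OCC(=O)NCc3cc(C)cc(C)c3)c2c1` gives 92000 nM. Compound 2 `COc1ccc2nc(C)cc(OCC(=O)Nc3ccccn3)c2c1` gives 29000 nM. Compound 3 `COc1ccc2nc(C)cc(OCC(=O)Nc3c(C)cncc3C)c2c1` gives 12000 nM, which is the lowest of the three numbers. The steps among them all move downward: a 3.2-fold lower number from compound 1 to compound 2 (0.50 log units; beyond the scatter), a 7.7-fold lower number from compound 1 to compound 3 (0.88 log units; beyond the scatter) and a 2.4-fold lower number from compound 2 to compound 3 (0.38 log units; beyond the scatter). Each of these exchanges one group on the amide-type nitrogen for another.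

Compound 4 `COc1ccc2nc(C)cc(OCC(=O)NNC(=O)c3ccncc3)c2c1` differs from compound 3 in the same place: ((pyridin-4-yl)carbonyl)amino in place of 3,5-dimethylpyridin-4-yl on an amide-type nitrogen. Among the compounds with values here, none of the measured steps covers this exact change; the steps only show that swapping the group on that nitrogen has shifted this assay by modest amounts, and that the two groups with a ring nitrogen gave lower numbers than the dimethylbenzyl group of compound 1. The new group removes both methyl groups of compound 3 and brings in an amide-type linker with one hydrogen-bond donor and two acceptors. On this basis a modest step upward from compound 3 is expected, though its size is uncertain and could fall within the scatter: the expected step is a 2.1-fold higher number from compound 3 to compound 4 (0.32 log units; beyond the scatter). Compound 4 is therefore estimated at 25000 nM, with a likely range from 8000 nM to 80000 nM.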

Compound 4, solubility: >= 375000 nM
Compound 4: no number, only a limit; the forecaster's own chance of this, stated with the estimate: 0%; middle value at least 15-fold (1.17 log units) away from the limit.
By their numbers in this assay, from the lowest: compound 3; then compound 2; then compound 1. At a limit, above all of these: compound 4.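

In this assay, within the data shown here, swaps on the amide-type nitrogen had so far given only modest steps, but ((pyridin-4-yl)carbonyl)amino gives large ones: an at least 31-fold higher number from compound 3 to compound 4 (1.49 log units; beyond the scatter) and an at least 12-fold higher number from compound 2 to compound 4 (1.11 log units; beyond the scatter). It also overtakes the 3,5-dimethylbenzyl group, which had given the highest number of the series, with an at least 4.0-fold higher number from compound 1 to compound 4 (0.61 log units; beyond the scatter), so the three earlier compounds had shown only part of the span this position can reach. Compound 4 stands at a limit of this assay and not at a number, so each of these steps gives only a smallest possible size: the limit of >= 375000 nM in this assay, at which 1 of the 4 values shown sits.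

The compounds shown leave open how far the true value of compound 4 lies from this limit, and whether the rise goes with the carbonyl and amino linker or with the pyridin-4-yl ring, since this single exchange brings in both together. A plain phenyl ring on the same linker, or an acetyl group on that nitrogen, would begin to separate these two parts, and it would show how much of the change each one carries.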